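The source may report more compounds than this note shows. Statements on the series, on what has been measured and on what is new or still open speak of the compounds shown alone.

Compound 3 `Cc1nc2c(OCc3ccccc3)cccn2c1C[S+](C)[O-]` stands lowest of the three numbers in a functional assay on the whole organism with Rattus norvegicus as the target, with a stated time of 4 h, at a dose of 40 mg/kg by the intraperitoneal route (a higher number here means more inhibition at the dose given (going by the name of the read-out), a lower number less inhibition), giving 0%; compound 2 `CCSCc1c(C)nc2c(OCc3ccccc3)cccn12` gives 36% and compound 1 `CC(=O)c1c(C)nc2c(OCc3ccccc3)cccn12` gives 57%, both beyond the scatter from compound 3. Compound 4 `Cc1nc2c(OCc3ccccc3)cccn2c1Cl` differs from compound 3 by one chlorine atom in place of a group of 4 heavy atoms (2 carbon, 1 oxygen, 1 sulfur; no ring), on an aromatic carbon. Among the measured compounds shown here, no measured step exchanges that group for chlorine, so none bears directly on this change. What the series does show is that exchanging the group on this aromatic carbon shifts the read-out widely: a number 57 percentage points lower from compound 1 to compound 3 (beyond the scatter) and a number 36 percentage points lower from compound 2 to compound 3 (beyond the scatter), both large, and a number 21 percentage points lower from compound 1 to compound 2 (beyond the scatter), modest. With compound 3 at the floor of the scale, any step beyond the scatter can only be upward; the expected step is a number 25 percentage points higher from compound 3 to compound 4 (beyond the scatter). Compound 4 is estimated at 25%, range 0% to 60%.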

Compound 4, a percentage reported as inhibition, in the whole organism at one dose (the size of the read-out at that dose, not a potency): 93%
Compound 4: the middle estimate sits 68 percentage points below what was measured; measured number outside the range, above it.
By their numbers in this assay, from the lowest: compound 3; then compound 2; then compound 1; then compound 4.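

In this assay chloro on this aromatic carbon stands above all three earlier groups: a number 36 percentage points higher from compound 1 to compound 4 (beyond the scatter) and a number 57 percentage points higher from compound 2 to compound 4 (beyond the scatter) and a number 93 percentage points higher from compound 3 to compound 4 (beyond the scatter) are all large steps. A high number at this position therefore needs neither a group of several heavy atoms nor a hydrogen-bond acceptor on it. Nothing measured here explains why chloro gives the highest number of the four.

Open, from the compounds shown here alone, is whether the high number is specific to chlorine or also holds for fluorine, bromine or a methoxy group on this carbon. Going by these compounds, an amine or a carboxylic acid here remains equally open.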